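The compounds below may be only part of what the source reports. "The series", "measured", "known", "first", "only" and "open" are said of these compounds alone.

Working notes on the series. Compound 1 `CCCN(CCC)c1nc(C(C)(C)C)ccc1CNC(=O)C(C)c1ccc(NS(C)(=O)=O)c(F)c1` carries a dipropylamino group on the shared core; in an assay on cells for antagonist activity at transient receptor potential cation channel subfamily V member 1 (Homo sapiens), read by FLIPR and calcium flux, with a stated time of 6 min (a lower number here means a stronger inhibitor, a higher number a weaker inhibitor), compound 1 gives 2.5 nM. Compound 2 `CC(C)COc1nc(C(C)(C)C)ccc1CNC(=O)C(C)c1ccc(NS(C)(=O)=O)c(F)c1` has isobutoxy in that place, and in this assay compound 2 gives 0.6 nM. Going by the values given here, the single measured step, a 4.2-fold lower number from compound 1 to compound 2 (0.62 log units; beyond the scatter), is the only comparison available, and it leaves compound 2 with the lowest of the two numbers.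

Compound 3 `CCOCCOc1nc(C(C)(C)C)ccc1CNC(=O)C(C)c1ccc(NS(C)(=O)=O)c(F)c1` keeps everything else of compound 2 and alters only the alkoxy chain: ethoxymethyl in place of isopropyl on a saturated chain carbon bound to an oxygen on an aromatic ring. Among the compounds with values here, no measured step touches this chain; the step from compound 1 to compound 2 exchanged the whole group on the aromatic carbon, dipropylamino for isobutoxy, and so bears on the present change only loosely. With the attachment through oxygen retained and the change confined to the outer part of the chain, a step of modest size at most is expected in this assay, in either direction, most likely not beyond the scatter. Compound 3 is therefore estimated at 1.2 nM, with a range from 0.4 nM to 4 nM. The expected step is a 2.0-fold higher number from compound 2 to compound 3 (0.30 log units; within the scatter).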

Compound 3, inhibition constant: 23.9 nM
Beside the measured number, compound 3's estimate is 20-fold (1.30 log units) below it; measured number outside the range, above it.
By their numbers in this assay, from the lowest: compound 2; then compound 1; then compound 3.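

In this assay, going by these compounds alone, the outer part of the alkoxy chain proves to be a sensitive place: ethoxymethyl in place of isopropyl on a saturated chain carbon bound to an oxygen on an aromatic ring gives a 40-fold higher number from compound 2 to compound 3 (1.60 log units; beyond the scatter) and marks this as the largest step so far. Attachment through oxygen therefore does not by itself secure a low number, since the exchange of the whole group on the aromatic carbon, dipropylamino for 2-ethoxyethoxy, gives a 9.6-fold higher number from compound 1 to compound 3 (0.98 log units; beyond the scatter) and runs opposite to the step from dipropylamino to isobutoxy, so that compound 1 now lies between the two oxygen-linked compounds. Nothing available here accounts for the size of either step or for this reversal in direction.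

The two oxygen-linked compounds alone cannot separate the effect of the oxygen inside the chain from that of the chain's extent, and a pentyloxy group, an all-carbon chain, would bear directly on that question. As far as these compounds go, it also remains open how a terminal hydroxyl, an amine or a shorter group such as ethoxy would read at this place in this assay.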